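Lengthening the Chain Toward the Phenyl Ring

This account rests on a few compounds, and the source may have more. Where it says the series, first, only, none or still open, it means among the compounds named here.

Among the compounds with values here, compound 1 `O=C(CCCCCCCCCCc1ccccc1)CC(=O)N[C@H]1CCOC1=O` is the only compound here with a numerical result in a functional assay on NCI-H630 cells (Homo sapiens) for cytotoxicity, read by sulforhodamine B assay, with a stated time of 5 days; on this read-out lower numbers stand for stronger inhibition and higher numbers for weaker inhibition: compound 1 gives 23000 nM. Compound 2 `O=C(CCCCc1ccccc1)N[C@H]1CCOC1=O` returns only a limit of the assay, > 100000 nM, in this assay. That result is the limit of > 100000 nM in this assay, at which 1 of the 2 values shown sits. Compound 3 `O=C(CCCCCCCCCCCc1ccccc1)CC(=O)N[C@H]1CCOC1=O` differs from compound 1 by benzyl in place of phenyl on a saturated chain carbon, ten or more bonds along the chain from a carbonyl carbon. Within the data shown here, no step between two measured compounds is available to guide the guess, so the expected shift for compound 3 is a 1.3-fold lower number from compound 1 to compound 3 (0.11 log units; within the scatter), a change no larger than the usual scatter. Compound 3 is therefore estimated at 18000 nM in this assay, with a range from 8000 nM to 45000 nM.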

Compound 3, half-maximal inhibitory concentration: 33000 nM
Compound 3: the middle estimate sits 1.8-fold (0.26 log units) below what was measured; low and high end bracket the measured number.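

In this assay benzyl in place of phenyl, one carbon more on the long chain, gives a 1.4-fold higher number from compound 1 to compound 3 (0.16 log units; within the scatter) and so leaves the result effectively unchanged. This first step between two measured compounds shows that, on a saturated chain carbon, this small change is tolerated. Nothing measured here bears on why the step is so small.

Still open, going by these compounds, is whether phenethyl or 3-phenylpropyl at this place would also leave the result unchanged. Also open, on these data alone, is what an amine or a carboxylic acid at the chain end, in place of the phenyl ring, would do.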